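A few compounds are considered here, and "the series" means these few. Any claim that something is new, unique, unknown or untested is made for them only; others in the source may bear on it.

Going by the values given here, in a functional assay on MDA-MB-453 cells (Homo sapiens) for cytotoxicity, read by MTT assay, with a stated time of 72 h (on this read-out higher numbers stand for weaker inhibition and lower numbers for stronger inhibition), compound 1 `CC(C)(C)C1=CC(=O)C=C(NCCC(=O)O)C1=O` gives 94100 nM, the highest of the three numbers so far and therefore the weakest inhibition. By comparison, compound 2 `CC1=CCC[C@H]2[C@](C)(CC3=CC(=O)C=CC3=O)[C@@H](C)CC[C@]12C` gives 16700 nM and compound 3 `CC1=CCC[C@H]2[C@](C)(CC3=CC(=O)C=C(NCCC(=O)O)C3=O)[C@@H](C)CC[C@]12C` gives 3310 nM.

The next compound to consider is compound 4 `CC(C)(C)C1=CC(=O)C=CC1=O`, which differs from compound 1 in one place: hydrogen in place of (2-carboxyethyl)amino on a double-bonded ring carbon. Hydrogen replaces (2-carboxyethyl)amino on a double-bonded ring carbon, while the tert-butyl group stays.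

Among the compounds with values here, only one measured step bears on this change: a 5.0-fold lower number from compound 2 to compound 3 (0.70 log units; beyond the scatter). That step adds the group that compound 4 loses, so read in reverse it points towards a higher number for compound 4 than for compound 1. The guide is a single pair, however, and compound 2 and compound 3 carry a much larger group where compound 1 has its tert-butyl group. Within the data shown here, no pair with the tert-butyl group has been measured yet, so a smaller step in the same direction seems a cautious expectation, and the range must stay wide.

The expected change in this assay is a 2.1-fold higher number from compound 1 to compound 4 (0.33 log units; beyond the scatter). For compound 4 the estimated value is 200000 nM, with an expected range from 40000 nM to 600000 nM.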

Compound 4, half-maximal inhibitory concentration: 56800 nM
Beside the measured number, compound 4's estimate is 3.5-fold (0.55 log units) above it; low and high end bracket the measured number.
By their numbers in this assay, from the lowest: compound 3; then compound 2; then compounds 4 and 1 (each within the scatter of the next).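

Hydrogen in place of (2-carboxyethyl)amino on a double-bonded ring carbon gives, in this assay, a 1.7-fold lower number from compound 1 to compound 4 (0.22 log units; within the scatter), so with the tert-butyl group present this change has no effect that can be told from the scatter. The clear step seen with the much larger group of compound 2 and compound 3 therefore does not carry over to this core, and what the change does depends on the rest of the molecule: the same change on two cores in this assay, a 5.0-fold lower number (0.70 log units; beyond the scatter) from compound 2 to compound 3 and a 1.7-fold higher number (0.22 log units; within the scatter) from compound 4 to compound 1, 8.4-fold (0.92 log units) apart, beyond the scatter of two such steps. This is a contrast between two pairs of compounds, not yet a general rule.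

On these data alone, it remains open which part of the (2-carboxyethyl)amino group matters on the core of compound 3, and whether a plain amine, a shorter or longer chain ending in a carboxylic acid, or the methyl ester of that acid would give the same step. As far as these compounds go, it is also open how the step would look with a cyclohexyl group in place of the tert-butyl group, a case that could show how the result on one core turns into the result on the other.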